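The source may report more compounds than this note shows. Statements on the series, on what has been measured and on what is new or still open speak of the compounds shown alone.

Measured so far in a functional assay on DU-145 cells (Homo sapiens) for cytotoxicity, read by MTT assay, with a stated time of 24 h; a lower number here means a stronger inhibitor, a higher number a weaker inhibitor:

compound 1, `O=C1/C(=C/c2ccccc2F)CN(Cc2cn(Cc3ccccc3F)nn2)C/C1=C\c1ccccc1F`, gives 10600 nM
compound 2, `O=C1/C(=C/c2ccccc2F)CN(Cc2cn(Cc3ccccc3Cl)nn2)C/C1=C\c1ccccc1F`, gives 7500 nM
compound 3, `Cc1ccc(/C=C2\CN(Cc3cn(Cc4ccccc4F)nn3)C/C(=C\c3ccc(C)cc3)C2=O)cc1`, gives 9500 nM

Compounds 1 and 2 share one core and differ only in chloro in place of fluoro on an aromatic carbon. The step this change made, a 1.4-fold lower number from compound 1 to compound 2 (0.15 log units; within the scatter), lies within the scatter of the method, so the two values show no separable difference.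

Compound 3 carries a different core; the difference between the two cores is not broken down here. Its value sits close to that of compound 1 and that of compound 2, all three within the scatter of one another, so no order among them can be claimed.

Compound 4, `Cc1ccc(/C=C2\CN(Cc3cn(Cc4ccccc4Cl)nn3)C/C(=C\c3ccc(C)cc3)C2=O)cc1`, is not yet measured. It stands to compound 3 as compound 2 stands to compound 1: the difference is chloro in place of fluoro on an aromatic carbon, and the place line of the change reads the same word for word in both pairs, so it is the same change on the other core. Among the compounds with values here, the only comparison available, compound 1 to compound 2, gives a step within the scatter; with no second example of the change on any core, the expectation for compound 4 rests on that single step alone.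

For compound 4 in this assay the step expected is a 1.4-fold lower number from compound 3 to compound 4 (0.13 log units; within the scatter), carried over from the measured pair. Compound 4 is therefore estimated at 7000 nM, with a range from 4000 nM to 14000 nM allowing for the scatter seen in compounds 1, 2 and 3.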

Compound 4, half-maximal inhibitory concentration: 10500 nM
For compound 4 the middle estimate is 1.5-fold (0.18 log units) below the measured one; measured number inside the range.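

On the core of compound 3, replacing 2-fluorobenzyl with 2-chlorobenzyl gives in this assay a 1.1-fold higher number from compound 3 to compound 4 (0.04 log units; within the scatter), so compound 3 and compound 4 show no separable difference. Set beside the earlier pair, the swap gives steps that cannot be told apart across the two cores: the same change on two cores in this assay, a 1.4-fold lower number (0.15 log units; within the scatter) from compound 1 to compound 2 and a 1.1-fold higher number (0.04 log units; within the scatter) from compound 3 to compound 4, 1.6-fold (0.19 log units) apart, within the scatter of two such steps. Within the data shown here, this shows that in the two available pairs the swap leaves the number within the scatter on both cores, but with only two pairs and neither step separable from the scatter, it does not establish a direction or size for the swap, nor does it show that the result would hold on any other core.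

The compounds shown carry only fluoro or chloro at this place, so it remains open whether a methoxy group, an amine or a carboxylic acid on the same aromatic carbon would give a step beyond the scatter in this assay. Also open, from the compounds shown here alone, is whether a longer chain in place of the 2-fluorobenzyl or 2-chlorobenzyl group would give a number separable from those of compound 1, compound 2, compound 3 and compound 4.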